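This account rests on a few compounds, and the source may have more. Where it says the series, first, only, none or still open, it means among the compounds named here.

Notes on the series. The shared core of compound 1 `CC1=C(C(=O)OCc2ccccc2)C(c2ccco2)NC(=O)N1` carries a furan-2-yl on the saturated ring carbon. In an assay on membranes from CHO cells for displacement of a labelled ligand from adenosine receptor A1 (Homo sapiens), read by scintillation counting, with a stated time of 60 min, tested at 1 uM (on this read-out lower numbers stand for less inhibition and higher numbers for more inhibition at the one concentration tested (going by the name of the read-out)), compound 1 gives 36%, the highest of the three numbers in hand. Compound 3 `CC1=C(C(=O)OCC(C)C)C(c2cccs2)NC(=O)N1` gives 25% in this assay, a number lower than that of compound 1 by more than the scatter, and compound 2 `COC(=O)C1=C(C)NC(=O)NC1c1ccoc1` gives 8%, the furthest below compound 1. Going by the values given here, compound 2 and compound 3 each differ from compound 1 in more than one place, so no single-change step between measured compounds is available.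

Compound 4 `CC1=C(C(=O)OCc2ccccc2)C(c2ccsc2)NC(=O)N1` differs from compound 1 in one place: thiophen-3-yl in place of furan-2-yl on a saturated ring carbon. Among the compounds with values here, no measured pair isolates this change. The three measured compounds all give moderate inhibition, so a change of modest size is expected here. The step from compound 1 to compound 4 is expected to be small, not beyond the scatter in either direction: a number 4 percentage points lower from compound 1 to compound 4 (within the scatter) is the estimate. Compound 4 is thus expected to give 32% in this assay, within 15% to 50%.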

Compound 4, a percentage reported as inhibition, at one concentration (the size of the read-out at that concentration, not a potency): 57%
For compound 4 the middle estimate is 25 percentage points below the measured one; measured number above the stated range.
By their numbers in this assay, from the lowest: compound 2; then compound 3; then compound 1; then compound 4.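

In this assay, going by these compounds alone, the exchange of furan-2-yl for thiophen-3-yl on the saturated ring carbon gives a number 21 percentage points higher from compound 1 to compound 4 (beyond the scatter), the first single-change step, so the number at this position responds to a swap between two five-membered aromatic rings. The two groups match in heavy atoms, hydrogen-bond donors, hydrogen-bond acceptors and net charge, yet they differ in both the hetero atom, oxygen against sulfur, and the ring attachment, so this one step joins two variables. No measurement in hand speaks to the origin of the step.

As far as these compounds go, it remains open whether the sulfur or the ring attachment carries the step; a thiophen-2-yl on the core of compound 1 would separate the two. Also open, from the compounds shown here alone, is how a six-membered aromatic group such as phenyl or pyridin-3-yl would read at this place.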